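A few compounds are considered here, and "the series" means these few. Any claim that something is new, unique, unknown or untested is made for them only; others in the source may bear on it.

Of the compounds shown here, three sharing one core have been measured in an ADME assay on microsomes from liver (Homo sapiens) for pharmacokinetics, read by LC-MS, with a stated time of 60 min, tested at 1 uM; on this read-out lower numbers stand for slow clearance and higher numbers for fast clearance. Compound 1 (`O=C(NCc1ccc(S(=O)(=O)C2CCCOC2)cc1)N1Cc2ccncc2C1`) gives 7 mL/min/kg, compound 2 (`CN1CCC(S(=O)(=O)c2ccc(CNC(=O)N3Cc4ccncc4C3)cc2)CC1`) gives 11 mL/min/kg, and compound 3 (`O=C(NCc1ccc(S(=O)(=O)N2CCC[C@H](O)C2)cc1)N1Cc2ccncc2C1`) gives 8 mL/min/kg. Compound 3 cannot be told apart from either of the others, since all three numbers lie within the usual scatter of one another.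

Compound 4 (`O=C(NCc1ccc(S(=O)(=O)N2CC3(CCOCC3)C2)cc1)N1Cc2ccncc2C1`) differs from compound 3 in one place: a group of 9 heavy atoms (7 carbon, 1 nitrogen, 1 oxygen; one four-membered non-aromatic ring with 1 hetero atom, one six-membered non-aromatic ring with 1 hetero atom) in place of a group of 7 heavy atoms (5 carbon, 1 nitrogen, 1 oxygen; one six-membered non-aromatic ring with 1 hetero atom), on a sulfonyl sulfur.

For the measured compounds named here, three measured steps bear on this change, as each swaps the group on a sulfonyl sulfur. They are a 1.1-fold higher number from compound 1 to compound 3 (0.06 log units; within the scatter), a 1.4-fold lower number from compound 2 to compound 3 (0.14 log units; within the scatter) and a 1.6-fold higher number from compound 1 to compound 2 (0.20 log units; within the scatter). All three stay within the scatter, so swaps at this place have not yet moved this assay measurably. However, no measured compound has a four-membered non-aromatic ring there, so the expectation is an extrapolation. No step beyond the scatter is expected, and the estimated step is a 1.1-fold higher number from compound 3 to compound 4 (0.05 log units; within the scatter).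

For compound 4 the expected value is 9 mL/min/kg, with an estimated range from 5 mL/min/kg to 17 mL/min/kg.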

Compound 4, clearance: 13 mL/min/kg
For compound 4 the middle estimate is 1.4-fold (0.16 log units) below the measured one; low and high end bracket the measured number.
By their numbers in this assay, from the lowest: compounds 1, 3, 2 and 4 (each within the scatter of the next).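

The group with a four-membered non-aromatic ring is new at this place on the sulfonyl sulfur, yet in this assay it stays within the scatter of all three earlier groups, with a 1.6-fold higher number from compound 3 to compound 4 (0.21 log units; within the scatter) and a 1.2-fold higher number from compound 2 to compound 4 (0.07 log units; within the scatter) and a 1.9-fold higher number from compound 1 to compound 4 (0.27 log units; within the scatter) as its steps. The change also removes the one hydrogen-bond donor of 3-hydroxypiperidin-1-yl and defined stereocentre, and no step beyond the scatter comes with it. No measurement shown speaks to what lies behind these numbers.

All four groups shown at this place contain a non-aromatic ring, so it remains open whether any group here can move this read-out beyond the scatter. An open-chain group such as dimethylamino, or a group carrying a carboxylic acid, on the sulfonyl sulfur would extend the comparison.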